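A Thioether Arm Replaces the Pentylamino Chain

The source may hold more compounds than are shown below. What is called first, only, known or untested is meant among the compounds shown, and "the series" means these compounds.

Compound 1: `O=[N+]([O-])c1cccc2c1CCN(c1ncnc3c1nc1n3[C@@H]3O[C@H](CO1)[C@@H](O)[C@H]3O)C2` — 7410000 nM
Compound 2: `CCCCCNc1ncnc2c1ncn2[C@@H]1O[C@H](CO)[C@@H](O)[C@H]1O` — 13500 nM
Compound 3: `CCCC(C)n1cnc2c(SCc3ccccn3)nc(N)nc21` — 41700 nM

Of the compounds shown here, three have so far been measured in an assay on isolated protein for binding affinity to Equilibrative nucleoside transporter 1 (Homo sapiens); on this read-out higher numbers stand for weaker inhibition and lower numbers for stronger inhibition. Compound 2 has the lowest of the three numbers. Its nearest neighbour is compound 3, whose value lies higher by a margin beyond the usual scatter, while compound 1 stands furthest away, very much higher and likewise beyond the scatter. Compound 2 is therefore the strongest inhibitor among the three.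

The next compound, compound 4 `OC[C@H]1O[C@@H](n2cnc3c(CSc4ccccc4Cl)ncnc32)[C@H](O)[C@@H]1O`, has not yet been measured in this assay. It departs from compound 2 in a single place: ((2-chlorophenyl)sulfanyl)methyl in place of pentylamino on an aromatic carbon. The pentylamino group of compound 2 leaves, and a ((2-chlorophenyl)sulfanyl)methyl group enters on the same aromatic carbon of the two-ring system.

Going by the values given here, no pair of measured compounds differing in one place is available, so nothing directly fixes the size of this step. The expectation rests only on the values shown: compound 2 gives 13500 nM in this assay, and the rather different compound 3 gives 41700 nM. On this basis the step of a 4.4-fold higher number from compound 2 to compound 4 (0.65 log units; beyond the scatter) is expected to lie beyond the scatter, toward weaker inhibition. Compound 4 is estimated at 60000 nM in this assay, within a range from 10000 nM to 400000 nM.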

Compound 4, half-maximal inhibitory concentration: 1780 nM
The estimate for compound 4 lay 34-fold (1.53 log units) above the measured number; the measured number lies below the stated range.
By their numbers in this assay, from the lowest: compound 4; then compound 2; then compound 3; then compound 1.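

In this assay, going by these compounds alone, placing ((2-chlorophenyl)sulfanyl)methyl instead of pentylamino on this aromatic carbon gives a 7.6-fold lower number from compound 2 to compound 4 (0.88 log units; beyond the scatter), the first change at this position whose size can be read. The position therefore accepts a substituent carrying a six-membered aromatic ring of carbon only, and the step runs toward stronger inhibition even though the hydrogen-bond donor counted on pentylamino is lost and the group now attaches through carbon rather than nitrogen. No supporting measurement accounts for the size or direction of this step.

The exchange alters the attachment, the chain, the sulfur, the ring and the chlorine together, so the compounds shown do not reveal which of these features accompanies the stronger inhibition. On these data alone, a phenylsulfanylmethyl group without the chlorine, a (2-chlorophenoxy)methyl group with oxygen in place of sulfur, or a benzylamino group on the same carbon would each separate part of this single step, and whether larger or smaller groups here go further also remains open.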